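Cytotoxicity limits across the biaryl amide series

The source may report more compounds than this note shows. Statements on the series, on what has been measured and on what is new or still open speak of the compounds shown alone.

Measured compounds
Compound 1, `CCOC(=O)CCCCCOc1cccc(CN(C(=O)c2ccc(-c3cccc4ccccc34)cc2)C(C)C)c1`: in an ADME assay on HEK293 cells (Homo sapiens) for cytotoxicity, read by CellTiter-Glo and resazurin assay, with a stated time of 72 h (a lower number here means that less compound is needed, a higher number that more compound is needed for the effect), compound 1 gives > 26000 nM, which is a limit of the assay.
Compound 2, `CCOC(=O)CCCCCOc1cccc(CN(C(=O)c2ccc(-c3cccnc3)cc2)C(C)C)c1`: in this assay compound 2 gives > 26000 nM, again a limit.
Compound 3, `CCOC(=O)CCCCCOc1cccc(CN(C(=O)c2ccc(-c3cccc(OCc4ccccc4)c3)cc2)C(C)C)c1`: in this assay compound 3 gives > 26000 nM, also a limit.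

Compound 3 stands at the limit of this assay, as do the other two values shown, so that the limit of > 26000 nM in this assay, at which 3 of the 3 values shown sit, describes the whole set. Among the compounds with values here, the single step between measured compounds, a step that the two limits leave unreadable from compound 1 to compound 2, is unreadable because both of its values are limits; it gives no size and no direction.

Compound 4 is `CCOC(=O)CCCCCOc1cccc(CN(C(=O)c2ccc(-c3cccc(Cl)c3)cc2)C(C)C)c1`. Against compound 3 the change is chloro in place of benzyloxy on an aromatic carbon. Within the data shown here, no measured step bears on this change: the one step available, a step that the two limits leave unreadable from compound 1 to compound 2, alters a different part of the shared core and is itself unreadable. With all three measured values sitting at the limit and no readable step anywhere, no effect beyond the scatter is expected in this assay.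

Compound 4 is therefore expected to give 40000 nM in this assay, most likely reported again as a limit, with the estimate spanning 20000 nM to 100000 nM. The step that this estimate means, a step that the limit leaves unreadable from compound 3 to compound 4, is expected to be within the scatter.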

Compound 4, half-maximal effective concentration: > 18400 nM
Compound 4: no number, only a limit; the forecaster's own chance of this, stated with the estimate: 85%; the middle value is on the limit's open side.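

In this assay compound 4 gives > 18400 nM, which is a limit. Compound 1, compound 2 and compound 3 also stand at limits, so the steps from each of them to compound 4 cannot be read. Open is the concentration at which any of these compounds reaches a half-maximal effect, and whether naphthalen-1-yl, pyridin-3-yl, benzyloxy and chloro differ at all in this assay.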